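Methoxy for Fluoro in a Series Sitting at the Limit

This account rests on a few compounds, and the source may have more. Where it says the series, first, only, none or still open, it means among the compounds named here.

Three compounds sharing one core were tested in a functional assay on DU-145 cells (Homo sapiens) for cytotoxicity, read by sulforhodamine B assay, with a stated time of 48 h; on this read-out higher numbers stand for weaker inhibition of growth and lower numbers for stronger inhibition of growth. Compound 1 `N#Cc1ccc(Nc2nc(Oc3ccnc4ccccc34)nc(N3CCN(C(c4ccccc4)c4ccc(Cl)cc4)CC3)n2)cc1C(F)(F)F` reached only the limit of the assay, > 100000 nM. Compound 3 `COc1ccc(CN2CCN(c3nc(Nc4ccc(C#N)c(C(F)(F)F)c4)nc(Oc4ccnc5ccccc45)n3)CC2)c(OC)c1OC` likewise gave only a limit, > 100000 nM. Compound 2 `N#Cc1ccc(Nc2nc(Oc3ccnc4ccccc34)nc(N3CCN(c4ccc(F)cc4)CC3)n2)cc1C(F)(F)F` also gave nothing beyond a limit, > 100000 nM. For the measured compounds named here, since every value shown sits at that same limit, (the limit of > 100000 nM in this assay, at which 3 of the 3 values shown sit), compound 2 stands nowhere in particular among them: no number separates it from compound 1 or compound 3, and no measured pair tells how any single change moves the read-out here.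

Compound 4 `COc1ccc(N2CCN(c3nc(Nc4ccc(C#N)c(C(F)(F)F)c4)nc(Oc4ccnc5ccccc45)n3)CC2)cc1` is not yet measured. It differs from compound 2 by one change, methoxy in place of fluoro on an aromatic carbon. With every neighbour at the limit, the step expected in this assay is a step that the limit leaves unreadable from compound 2 to compound 4, that is, none beyond the scatter, most probably ending at the limit again. Compound 4 is therefore expected to give about 150000 nM, within a range from 30000 nM to 500000 nM, and more likely a limit than a number.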

Compound 4, concentration for 50% growth inhibition: > 100000 nM
Compound 4: no number, only a limit (the forecaster's own chance of this, stated with the estimate: 80%); the middle value is on the limit's open side.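

For the compounds shown here, compound 2 and compound 4 each gave only a limit, not a number, so no step from fluoro to methoxy can be read: the limit of > 100000 nM in this assay, at which 4 of the 4 values shown sit.

The compounds shown leave open whether any change to the shared core would give a measurable number here.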